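The source may hold more compounds than are shown below. What is called first, only, known or untested is meant among the compounds shown, and "the series" means these compounds.

Measured so far: compound 1 `O=C(N/N=C/c1ccccc1)c1cnccn1`, 100%; compound 2 `CCOc1cccc(/C=N/NC(=O)c2cnccn2)c1`, 69%.

Going by the values given here, in an ADME assay on J774 cells (Mus musculus) for cytotoxicity, read by MTT assay, with a stated time of 48 h, tested at 150 ug/mL (on this read-out lower numbers stand for a stronger effect and higher numbers for a weaker effect at the one concentration tested), compound 2 gives the lower of the two numbers; compound 1 stands higher, and the one step, a number 31 percentage points lower from compound 1 to compound 2 (beyond the scatter), lies beyond the scatter. Compound 3 `O=C(N/N=C/c1cccc(O)c1)c1cnccn1` differs from compound 2 by hydrogen in place of ethyl on an oxygen on an aromatic ring. Among the compounds with values here, the only measured step bearing on it is a number 31 percentage points lower from compound 1 to compound 2 (beyond the scatter), which added the ethoxy group and lowered the number by a large amount; compound 3 drops the ethyl but keeps the oxygen, so a partial reversal is expected, a number 16 percentage points higher from compound 2 to compound 3 (beyond the scatter), with considerable uncertainty. Compound 3 is estimated at 85%, range 65% to 100%.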

Compound 3, a percentage reported as activity, at one concentration (the size of the read-out at that concentration, not a potency): 88%
Compound 3: middle estimate off by 3 percentage points, on the low side; measured number inside the range.
By their numbers in this assay, from the lowest: compound 2; then compound 3; then compound 1.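

In this assay, the change at this aromatic carbon splits into two parts: hydroxy in place of hydrogen gives a number 12 percentage points lower from compound 1 to compound 3 (beyond the scatter), and hydrogen in place of ethyl on the oxygen gives a number 19 percentage points higher from compound 2 to compound 3 (beyond the scatter). The oxygen alone therefore already moves the number, and the ethyl on it carries the larger part of the drop seen with ethoxy. No measurement on hand accounts for either step.

Open, as far as these compounds go, is whether a longer chain on the oxygen, such as propoxy, lowers the number further. An amine in place of the hydroxy also remains to be placed against these values.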